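Adding a Second Chloro Group: An Expected Step

The source may report more compounds than this note shows. Statements on the series, on what has been measured and on what is new or still open speak of the compounds shown alone.

Compound 1, `C[C@@H](NC(=O)Nc1ccccc1Cl)c1ccccc1`, gives 101% in an ADME assay on the whole organism with Oryza sativa as the target, tested at 0.1 uM; a lower number here means a stronger effect, a higher number a weaker effect of the compound at the concentration tested.
Compound 2, `C[C@H](NC(=O)Nc1cccc(Cl)c1)c1ccccc1`, gives 103% in this assay.
Compound 3, `C[C@H](NC(=O)Nc1cc(Cl)ccc1Cl)c1ccccc1`, gives 100% in this assay.

The three measured values lie within the scatter of one another, so none of the three compounds can be set apart from the others in this assay. Compound 1 and compound 2 are built from the same atoms joined differently; the difference between the two cores is not broken down here. Compound 3 is derived from compound 2 by chloro in place of hydrogen on an aromatic carbon, and that change made a number 3 percentage points lower from compound 2 to compound 3 (within the scatter).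

Compound 4, `C[C@@H](NC(=O)Nc1c(Cl)cccc1Cl)c1ccccc1`, has not yet been measured. It is derived from compound 1 by chloro in place of hydrogen on an aromatic carbon. Within the data shown here, this is the same kind of change as the one from compound 2 to compound 3, though not the same: in compound 3 the entering chloro group is para to a chloro group, whereas in compound 4 it is meta to a chloro group.

For compound 4 the expected step is a number 1 percentage points lower from compound 1 to compound 4 (within the scatter), resting on the earlier step of a number 3 percentage points lower from compound 2 to compound 3 (within the scatter), which stayed within the scatter. Compound 4 is therefore estimated to give 100% in this assay, with the expected range running from 92% to 108%.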

Compound 4, a percentage reported as activity, at one concentration (the size of the read-out at that concentration, not a potency): 100%
For compound 4 middle estimate and measured number coincide at the digits printed; the range from low to high includes it.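

On the core of compound 1, chloro in place of hydrogen on an aromatic carbon, here ortho to a large group and meta to a chloro group, gives a number 1 percentage points lower from compound 1 to compound 4 (within the scatter). Set beside the earlier step in this assay, the same change reads alike on the two cores: the same change on two cores in this assay, a number 3 percentage points lower (within the scatter) from compound 2 to compound 3 and a number 1 percentage points lower (within the scatter) from compound 1 to compound 4, 2 percentage points apart, within the scatter of two such steps This shows only that the change produced no step beyond the scatter on either core; it does not show that a real effect of the same size carries from one core to the other, since neither step can be told from the scatter and two cores are a narrow basis for any rule about this series.

All the aromatic groups added in the compounds shown are chloro groups, so it remains open whether a methoxy group, a nitrile or an amine at the same place would produce a step beyond the scatter in this assay or would again leave the read-out within it. As far as these compounds go, it is equally open whether a longer chain in place of the methyl group would move the number, and whether any such step would then carry from one core to the other.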